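The source may hold more compounds than are shown below. What is called first, only, known or untested is meant among the compounds shown, and "the series" means these compounds.

In a functional assay on NCI-H226 cells (Homo sapiens) for inhibition, read by MTT assay, with a stated time of 48 h, tested at 10 uM (on this read-out lower numbers stand for less inhibition and higher numbers for more inhibition at the one concentration tested (going by the name of the read-out)), compound 1 `Cc1ccc(Nc2cc(NC(=O)Nc3c(Cl)cccc3Cl)ncn2)cc1C` gives 41.3%. Compound 2 `COc1cc(NC(=O)Nc2cc(Nc3cccc(C(C)(C)C)c3)ncn2)cc(OC)c1`, which carries a different aryl group on each end of the shared core, gives 40% in this assay. The two figures lie within the usual scatter of each other, so compound 1 stands in this pair at a level that cannot be told apart from that of compound 2, and the inhibition in this assay is level between them.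

Compound 3 `O=C(Nc1cc(Nc2ccc(F)c(Cl)c2)ncn1)Nc1c(Cl)cccc1Cl` has not yet been measured. It differs from compound 1 by 3-chloro-4-fluorophenyl in place of 3,4-dimethylphenyl on a nitrogen on an aromatic ring. Within the data shown here, no step between two measured compounds covers an exchange of this kind, so the expectation rests on the two measured values alone. Both measured compounds, with rather different aryl groups on the nitrogen, give nearly the same figure in this assay. The step from compound 1 to compound 3 is therefore expected to be a number 0.7 percentage points higher from compound 1 to compound 3 (within the scatter), a change that stays within the scatter, with no clear direction. In this assay compound 3 is expected to give about 42%, with a range from 25% to 60%.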

Compound 3, a percentage reported as inhibition, at one concentration (the size of the read-out at that concentration, not a potency): 47.3%
Estimate against measurement, compound 3: 5.3 percentage points below; the range from low to high includes it.
By their numbers in this assay, from the lowest: compounds 2, 1 and 3 (each within the scatter of the next).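

In this assay, among these compounds, the exchange of 3,4-dimethylphenyl for 3-chloro-4-fluorophenyl on a nitrogen on an aromatic ring gives the first step that can be read at this position, a number 6 percentage points higher from compound 1 to compound 3 (within the scatter), with the rest of the molecule unchanged. Two groups of the same heavy-atom count, one with only carbon and one carrying fluorine and chlorine, therefore cannot be told apart at this position, and trading the two methyl groups for these two halogens does not move the figure beyond the scatter. Nothing measured here bears on what lies behind this step.

The compounds shown leave open what a carboxylic acid, a dimethylamino group or a morpholine on this aryl ring would do to the figure, as every group at this place so far is a phenyl ring carrying only alkyl groups or halogens. Among the compounds shown here, compound 2 differs from compound 1 and compound 3 in more than one place, so no step to it can be read, and the part played by the aryl group at the other end of the shared core also stays open.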